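Swapping a heptyl amide for a chloropyrazolyl amide

The source may report more compounds than this note shows. Statements on the series, on what has been measured and on what is new or still open speak of the compounds shown alone.

Of the compounds shown here, three of one macrolide family have been measured in a physicochemical assay for lipophilicity, read by HPLC, measured as chromatographic lipophilicity, at pH 7.4; a lower number here means a more polar compound, a higher number a more lipophilic compound. Compound 1 `CC[C@H]1OC(=O)[C@H](C)[C@@H](O[C@H]2C[C@@](C)(OC)[C@@H](OCCCNC(=O)C3CCC3)[C@H](C)O2)[C@H](C)[C@@H](O[C@@H]2O[C@H](C)C[C@H](N(C)C)[C@H]2O)[C@](C)(O)C[C@@H](C)CN(C)[C@H](C)[C@@H](O)[C@]1(C)O` gives 2.62. Compound 2 `CCCCCCCC(=O)NCCCO[C@H]1[C@H](C)O[C@@H](O[C@H]2[C@H](C)[C@@H](O[C@@H]3O[C@H](C)C[C@H](N(C)C)[C@H]3O)[C@](C)(O)C[C@@H](C)CN(C)[C@H](C)[C@@H](O)[C@](C)(O)[C@@H](CC)OC(=O)[C@@H]2C)C[C@@]1(C)OC` gives 4.1, which places it second highest of the three numbers. Compound 3 `CCCCCCCC(=O)NCCCO[C@H]1[C@H](C)O[C@@H](O[C@H]2[C@H](C)[C@@H](O[C@@H]3O[C@H](C)C[C@H](N(C)C)[C@H]3O)[C@](C)(OC)C[C@@H](C)C(=O)[C@H](C)[C@@H](O)[C@](C)(O)[C@@H](CC)OC(=O)[C@@H]2C)C[C@@]1(C)OC` gives 6.02, the highest value; compound 3 differs from compound 2 in more than one place, so only its number is noted here.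

The step from compound 2 to compound 4 `CC[C@H]1OC(=O)[C@H](C)[C@@H](O[C@H]2C[C@@](C)(OC)[C@@H](OCCCNC(=O)c3c(C)nn(C)c3Cl)[C@H](C)O2)[C@H](C)[C@@H](O[C@@H]2O[C@H](C)C[C@H](N(C)C)[C@H]2O)[C@](C)(O)C[C@@H](C)CN(C)[C@H](C)[C@@H](O)[C@]1(C)O` changes the group on the carbonyl carbon: 5-chloro-1,3-dimethyl-1H-pyrazol-4-yl in place of heptyl on a carbonyl carbon

Among the compounds with values here, one measured step bears on this site. a number 1.48 log units higher from compound 1 to compound 2 (beyond the scatter). That step exchanged a small saturated ring for a seven-carbon chain and moved the number a long way; the change to compound 4 goes the other way, replacing the heptyl with a five-membered aromatic ring that carries two nitrogens and a chlorine. A large drop in this assay is therefore expected from compound 2 to compound 4, of the order of a number 1.00 log units lower from compound 2 to compound 4 (beyond the scatter).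

Compound 4 is thus estimated at 3.1 in this assay, within a range of 2.5 to 3.7.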

Compound 4, distribution coefficient: 2.52
Compound 4: the middle estimate sits 0.58 log units above what was measured; measured number inside the range.
By their numbers in this assay, from the lowest: compounds 4 and 1 (each within the scatter of the next); then compound 2; then compound 3.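

In this assay the exchange of heptyl for 5-chloro-1,3-dimethyl-1H-pyrazol-4-yl on the carbonyl carbon gives a number 1.58 log units lower from compound 2 to compound 4 (beyond the scatter) and so shows that a large step at this position is not confined to the cyclobutyl group that compound 1 carries. Setting the same aromatic ring in place of cyclobutyl gives a number 0.10 log units lower from compound 1 to compound 4 (within the scatter) and leaves the two amides indistinguishable in this assay even though one group is a small saturated ring and the other is a five-membered aromatic ring with nitrogen, chlorine and methyl groups on it. No measurement shown here accounts for how much the number moves at this position, or for how closely these two groups agree.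

As far as these compounds go, what a phenyl ring or a butyl chain on the same carbonyl carbon would give remains open, so the compounds do not show how the number runs between the cyclobutyl and heptyl amides. Also open, from the compounds shown here alone, is what the number would be for a pyrazolyl ring without its chlorine, and for the 5-chloro-1,3-dimethyl-1H-pyrazol-4-yl amide on the core of compound 3.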